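Chloro for butyl on a piperazine urea antagonist

The source may report more compounds than this note shows. Statements on the series, on what has been measured and on what is new or still open speak of the compounds shown alone.

The series rests on a shared piperazine urea core. In a functional assay on HEK293 cells for antagonist activity at transient receptor potential cation channel subfamily V member 1 (Rattus norvegicus) (on this read-out higher numbers stand for weaker inhibition and lower numbers for stronger inhibition), compound 1 `O=C(Nc1ccc(Oc2ccccc2)cc1)N1CCN(c2ncccc2C(F)(F)F)CC1` gives 916 nM. Compound 2 `CCCCc1ccc(NC(=O)N2CCN(c3ncccc3Cl)CC2)cc1` gives 203 nM in this assay, the lowest of the two numbers shown, and the gap from compound 1 lies beyond the scatter; the two structures differ in more than one place, so their values are simply set side by side. Compound 3 `O=C(Nc1ccc(Cl)cc1)N1CCN(c2ncccc2Cl)CC1` has not yet been measured in this assay. It differs from compound 2 by chloro in place of butyl on an aromatic carbon, on an aromatic carbon of a six-membered aromatic ring of carbon only, para to a large group. Within the data shown here, no measured pair shows this change alone. The step from compound 2 to compound 3 is expected to be modest and directed toward weaker inhibition, near the edge of the scatter, a 2.5-fold higher number from compound 2 to compound 3 (0.39 log units; beyond the scatter). For compound 3 the estimated value in this assay is 500 nM, within a range from 150 nM to 2000 nM.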

Compound 3, half-maximal inhibitory concentration: 2670 nM
The estimate for compound 3 lay 5.3-fold (0.73 log units) below the measured number; the measured number lies above the stated range.
By their numbers in this assay, from the lowest: compound 2; then compound 1; then compound 3.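

In this assay, among these compounds, the change of butyl to chloro on an aromatic carbon, para to a large group, can now be read alone for the first time, and it gives a 13-fold higher number from compound 2 to compound 3 (1.12 log units; beyond the scatter) with a large loss of inhibition. The position is therefore not indifferent to what it carries, at least between these two groups on this core. No measurement shown accounts for the size of this step.

The compounds shown leave open how a shorter chain such as ethyl, a longer chain such as hexyl or a branched group such as tert-butyl would compare with butyl at this carbon. They also leave open whether an amine or a methoxy group here would track with chloro or with butyl, and whether the step keeps its size when trifluoromethyl replaces the second chloro.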